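The compounds below may be only part of what the source reports. "The series", "measured", "known", "first", "only" and "open" are said of these compounds alone.

Measured so far in an assay on isolated protein for binding affinity to 5-hydroxytryptamine receptor 4 (Homo sapiens); a lower number here means a stronger inhibitor, a higher number a weaker inhibitor:
compound 1, `COc1ccc(-c2n[nH]cc2N2CCNCC2)cc1`, > 10000 nM
compound 2, `Clc1ccc(-c2n[nH]cc2N2CCNCC2)cc1`, > 10000 nM

Both of these values are limits of this assay rather than numbers. The value for compound 1 is a limit. The value for compound 2 is likewise a limit, so compound 2 stands only at the edge of what this assay reports, with no measured number of its own. The step that the two limits leave unreadable from compound 1 to compound 2 therefore cannot be read, its size being hidden by the two limits, as the limit of > 10000 nM in this assay, at which 2 of the 2 values shown sit, describes.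

Compound 3, `Cc1ccc(-c2n[nH]cc2N2CCNCC2)cc1`, is the next member of the series to be measured in this assay. It differs from compound 2 by methyl in place of chloro on an aromatic carbon. Going by the values given here, the only measured step, from compound 1 to compound 2, bears on this change in that it also swaps one small group for another on the same aromatic carbon, but its size is not readable. Among the compounds with values here, no step of readable size is available, so the expectation for compound 3 rests on both neighbours sitting at the limit. Compound 3 is expected to remain weak, with the step that the limit leaves unreadable from compound 2 to compound 3 estimated as negligible. The estimate for compound 3 in this assay is 15000 nM, ranging from 3000 nM to 60000 nM.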

Compound 3, inhibition constant: > 10000 nM
Compound 3: a limit, no number (the forecaster's own chance of this, stated with the estimate: 80%); the middle value lies beyond the limit too.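

Compound 3 gives > 10000 nM in this assay, which is a limit and not a number. The steps among compound 1, compound 2 and compound 3 therefore cannot be read: the limit of > 10000 nM in this assay, at which 3 of the 3 values shown sit. The compounds shown leave open whether any group on this aromatic carbon of the shared core gives a readable value in this assay.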